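Side-chain swap from compound 2 to compound 3

The source may report more compounds than this note shows. Statements on the series, on what has been measured and on what is new or still open speak of the compounds shown alone.

In a functional assay on the whole organism (Tail, strain ICR) with Mus musculus as the target, in the tail flick test, with a stated time of 120 min, at a dose of 25 umol/kg by the oral route (a higher number here means a stronger effect of the compound at the dose given, a lower number a weaker effect), compound 1 `O=C(O)[C@@H]1CCCN1C(=O)CN(c1nc(Cl)nc2[nH]cnc12)C1CC1` gives 23.6%, and compound 2 `N=C(N)NCCC[C@H](NC(=O)CN(c1nc(Cl)nc2[nH]cnc12)C1CC1)C(=O)OCc1ccccc1` gives 10.2%. Compound 2 thus stands lowest of the two numbers, with compound 1 the nearest value and higher by a margin beyond the usual scatter. Compound 3 `NCCCC[C@H](NC(=O)CN(c1nc(Cl)nc2[nH]cnc12)C1CC1)C(=O)OCc1ccccc1` differs from compound 2 as follows: a group of 2 heavy atoms (1 carbon, 1 nitrogen; no ring) in place of a group of 4 heavy atoms (1 carbon, 3 nitrogen; no ring), on a saturated chain carbon, four bonds along the chain from an amide-type nitrogen and a carbonyl carbon. Among the compounds with values here, no step between measured compounds that differ in one place is available, so the effect of this exchange has no precedent here. Compound 3 is expected to show a step of a number 1.8 percentage points higher from compound 2 to compound 3 (within the scatter), which is not beyond the scatter. Compound 3 is therefore estimated at 12% in this assay, between 0% and 30%.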

Compound 3, a percentage reported as activity, at one dose (the size of the read-out at that dose, not a potency): 16.8%
For compound 3 the middle estimate is 4.8 percentage points below the measured one, and the stated range covers the measured number.
By their numbers in this assay, from the lowest: compounds 2, 3 and 1 (each within the scatter of the next, the first and the last beyond it).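

In this assay, the first exchange read at this saturated chain carbon, aminomethyl in place of the group of 4 heavy atoms, gives a number 6.6 percentage points higher from compound 2 to compound 3 (within the scatter). At this single dose and time, the read-out therefore does not separate the two side chains, although the exchange removes the double bond outside aromatic rings and two of the three nitrogens of the leaving group. Nothing measured here bears on a cause for this result. Still open, going by these compounds, is whether a hydroxyl group or a longer chain ending in an amine at this carbon would give a step beyond the scatter.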